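The compounds below may be only part of what the source reports. "The series", "measured", "known", "first", "only" and "open" are said of these compounds alone.

For the measured compounds named here, compound 2 `CN(C)CCCn1nc(C2=C(c3cn(C)c4ccccc34)C(=O)N(c3ccccc3)C2=O)c2cccnc21` gives 1700 nM in a functional assay on K562 cells (Homo sapiens) for antiproliferative activity, read by MTT assay, with a stated time of 48 h (a lower number here means a stronger inhibitor, a higher number a weaker inhibitor), the lowest of the two numbers measured so far; its nearest neighbour is compound 1 `Cn1cc(C2=C(c3nn(CCCn4ccnc4)c4ncccc34)C(=O)N(c3ccccc3)C2=O)c2ccccc21`, which gives 5510 nM in this assay. Going by the values given here, the only measured step between them, a 3.2-fold lower number from compound 1 to compound 2 (0.51 log units; beyond the scatter), came with dimethylamino in place of 1H-imidazol-1-yl on a saturated chain carbon, three bonds along the chain from an aromatic nitrogen. Compound 3 `Cn1cc(C2=C(c3nn(CCCCn4ccnc4)c4ncccc34)C(=O)N(c3ccccc3)C2=O)c2ccccc21` has not yet been measured; it differs from compound 2 by (1H-imidazol-1-yl)methyl in place of dimethylamino on a saturated chain carbon, three bonds along the chain from an aromatic nitrogen. Among the compounds with values here, this change runs in the opposite sense to the one step seen, restoring an imidazole on the chain, so the expected effect in this assay is a modest rise of the number of roughly the size of that step, estimated as a 2.6-fold higher number from compound 2 to compound 3 (0.42 log units; beyond the scatter). Compound 3 is therefore expected to give about 4500 nM, in a range of 2000 nM to 11000 nM.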

Compound 3, half-maximal inhibitory concentration: 5030 nM
The estimate for compound 3 lay 1.1-fold (0.05 log units) below the measured number; the measured number falls inside the stated range.
By their numbers in this assay, from the lowest: compound 2; then compounds 3 and 1 (each within the scatter of the next).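

In this assay, the step with 4-(1H-imidazol-1-yl)butyl in place of 3-(dimethylamino)propyl is a 3.0-fold higher number from compound 2 to compound 3 (0.47 log units; beyond the scatter), so a second imidazole-bearing compound now stands apart from the dimethylamino compound. With the imidazole kept and only the chain longer, the step is a 1.1-fold lower number from compound 1 to compound 3 (0.04 log units; within the scatter), so at these two chain lengths, the length makes no visible difference, and the dimethylamino compound alone holds the lower number. Nothing given here explains either step.

On these data alone, it remains open whether a 4-(dimethylamino)butyl chain would keep the lower number of compound 2, or whether that number is tied to the shorter chain. Nor do these compounds show how a cyclic amine such as morpholine or piperidine, or a shorter chain carrying imidazole, would read at this position.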